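Fluoro for Nitro: Expecting the Cytotoxicity of Compound 4

The compounds below may be only part of what the source reports. "The series", "measured", "known", "first", "only" and "open" are said of these compounds alone.

Of the compounds shown here, three built on one shared core have been tested in an ADME assay on HEL cells (Homo sapiens) for cytotoxicity; on this read-out lower numbers stand for higher toxicity in this test and higher numbers for lower toxicity in this test. Compound 1 `O=C(COc1cccc2ccccc12)N/N=C/c1c(O)ccc2ccccc12` gives 4 ug/mL. Compound 2 `O=C(COc1cccc2ccccc12)N/N=C/c1ccc([N+](=O)[O-])cc1` gives 20 ug/mL, and compound 3 `C/C(=N\NC(=O)COc1cccc2ccccc12)c1ccccc1` gives 20 ug/mL. Compound 2 therefore stands level with compound 3 at the digits shown, the pair sharing the highest numbers of the three, while compound 1 lies furthest from compound 2 with a lower number, a gap beyond the usual scatter.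

Compound 4 `O=C(COc1cccc2ccccc12)N/N=C/c1ccc(F)cc1` has not yet been measured. It differs from compound 2 by fluoro in place of nitro on an aromatic carbon. Going by the values given here, no measured pair shows this change, so only a modest step is expected, a 1.3-fold lower number from compound 2 to compound 4 (0.12 log units; within the scatter), leaning toward a slightly lower number. Compound 4 is estimated at 15 ug/mL, with a range from 5 ug/mL to 40 ug/mL.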

Compound 4, minimum cytotoxic concentration: 100 ug/mL
Beside the measured number, compound 4's estimate is 6.7-fold (0.82 log units) below it; the measured number lies above the stated range.
By their numbers in this assay, from the lowest: compound 1; then compounds 2 and 3 (each within the scatter of the next); then compound 4.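

At the aromatic carbon para to a large group, fluoro in place of nitro is no small exchange: in this assay the change gives a 5.0-fold higher number from compound 2 to compound 4 (0.70 log units; beyond the scatter) and moves the read-out toward lower toxicity in this test. Going by these compounds alone, this is the first measured pair in the set that differs in one place, so it shows that this position alone can shift the number. Nothing measured here explains the rise.

Still open, on these data alone, is how other groups at this position, such as an amine or a carboxylic acid, would read. As far as these compounds go, it is also open whether fluoro for nitro would give a similar step on another core.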